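This account rests on a few compounds, and the source may have more. Where it says the series, first, only, none or still open, it means among the compounds named here.

Measured so far:
compound 1, `CC(=O)OCc1ccc2oc(=O)c(C(=O)Sc3cccc(Br)c3)cc2c1` — 70.9%
compound 2, `O=C(Oc1ccccc1)c1cc2cc([N+](=O)[O-])ccc2oc1=O` — 76.7%

In a functional assay on HT-1080 cells (Homo sapiens), read by transwell migration, with a stated time of 24 h, tested at 1 uM (a higher number here means a weaker effect of the compound at the concentration tested, a lower number a stronger effect), compound 1 gives 70.9% and compound 2 gives 76.7%. Compound 2 holds the higher of the two numbers, but the gap to compound 1 lies within the scatter, so the two are not separated by this assay. Within the data shown here, the two compounds differ in several places at once, and no single-change step between measured compounds is available.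

Compound 3, `O=C(Oc1cccc(F)c1)c1cc2cc([N+](=O)[O-])ccc2oc1=O`, differs from compound 2 by fluoro in place of hydrogen on an aromatic carbon. Among the measured compounds shown here, nothing among the measured compounds speaks to this change, so the step from compound 2 to compound 3 in this assay is expected to be small, with no direction and nothing beyond the scatter. For compound 3 the estimated value is 75%, with a range from 60% to 90%. The expected step, a number 1.7 percentage points lower from compound 2 to compound 3 (within the scatter), is accordingly within the scatter.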

Compound 3, a percentage reported as activity, at one concentration (the size of the read-out at that concentration, not a potency): 53.6%
For compound 3 the middle estimate is 21.4 percentage points above the measured one; the measured number lies below the stated range.
By their numbers in this assay, from the lowest: compound 3; then compounds 1 and 2 (each within the scatter of the next).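

In this assay the change from phenoxy to 3-fluorophenoxy reads a number 23.1 percentage points lower from compound 2 to compound 3 (beyond the scatter), so a stronger effect at the concentration tested comes with one added fluorine atom on the otherwise unchanged compound 2. This aromatic carbon, meta to a large group, is therefore sensitive to substitution, something the earlier pair could not show while it differed in several places at once. Nothing available explains why the fluoro change produces this step.

Open, from the compounds shown here alone, is whether the step belongs to fluoro itself or would also appear with chloro, methoxy or an amine on the same carbon. Also open, going by these compounds, is whether fluoro on another aromatic carbon of this ring would give a step of similar size, and whether this step carries over to other compounds.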